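From 1H-pyrrol-2-yl to 1H-pyrazol-1-yl on a shared core

A few compounds are considered here, and "the series" means these few. Any claim that something is new, unique, unknown or untested is made for them only; others in the source may bear on it.

Compound 1 `c1ccc2[nH]c(-n3cccn3)cc2c1` gives > 100000 nM as a limit of the assay
Compound 2 `COc1ccc2[nH]c(-c3ccc[nH]3)cc2c1` gives 33000 nM as a number

Within the data shown here, in a functional assay on OE21 cells (Homo sapiens) for cytotoxicity, read by MTT assay, with a stated time of 72 h (a lower number here means a stronger inhibitor, a higher number a weaker inhibitor), compound 2 gives 33000 nM as the only true number so far. The result for compound 1 is the limit of > 100000 nM in this assay, at which 1 of the 2 values shown sits, and not a number.

Compound 3 `COc1ccc2[nH]c(-n3cccn3)cc2c1` has not yet been measured. It keeps the core of compound 2 and changes one group: 1H-pyrazol-1-yl in place of 1H-pyrrol-2-yl on an aromatic carbon on an aromatic carbon of a five-membered aromatic ring with 1 nitrogen, next to the ring nitrogen. Among the measured compounds shown here, no measured pair of compounds shows this swap, so any forecast rests on thin ground. For the measured compounds named here, the only other guide is that 1H-pyrazol-1-yl also sits on compound 1, whose > 100000 nM is a limit. A small step towards a weaker inhibitor in this assay is therefore expected, and a result reported only as a limit is a real possibility. The estimated move is a 2.1-fold higher number from compound 2 to compound 3 (0.33 log units; beyond the scatter) in this direction. Compound 3 is expected at 70000 nM (estimated range 25000 nM to 100000 nM).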

Compound 3, half-maximal inhibitory concentration: > 100000 nM
Compound 3: a limit, no number (the forecaster's own chance of this, stated with the estimate: 45%); middle value at least 1.4-fold (0.15 log units) away from the limit.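

In this assay, putting 1H-pyrazol-1-yl in place of 1H-pyrrol-2-yl on the shared core gives an at least 3.0-fold higher number from compound 2 to compound 3 (0.48 log units; beyond the scatter), so at this place, on an aromatic carbon next to the ring nitrogen, the two five-membered rings are not interchangeable. Compound 3 gives a limit and not a number, so the size of this step is only a lower bound, because the reading stops at the end of the assay's range: the limit of > 100000 nM in this assay, at which 2 of the 3 values shown sit. The methoxy group adds no measurable effect here, since the compounds with 1H-pyrazol-1-yl, compound 1 without methoxy and compound 3 with it, both end at limits, and the step between them cannot be read.

A single pair cannot tell whether what matters is the hydrogen-bond donor that leaves with 1H-pyrrol-2-yl or the second ring nitrogen that enters with 1H-pyrazol-1-yl. Among these compounds, it also remains open how another group at this place, such as an amine or a carboxylic acid, would compare with compound 2, the only compound here with a true number.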